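Aryl swap at a cytotoxicity limit: compound 1 to compound 4

This account rests on a few compounds, and the source may have more. Where it says the series, first, only, none or still open, it means among the compounds named here.

Measured in an ADME assay on HepG2 cells (Homo sapiens) for cytotoxicity, read by MTT assay (a higher number here means a weaker inhibitor, a lower number a stronger inhibitor), all three values being limits:
- compound 1 `ClC(Cl)(Cl)c1nc(-c2ccccc2)c2ccccc2n1`: > 125000 nM
- compound 2 `FC(F)(F)c1cccc(-c2nc(C(Cl)(Cl)Cl)nc3ccccc23)c1`: > 125000 nM
- compound 3 `ClC(Cl)(Cl)c1nc(-c2ccc3ccccc3c2)c2ccccc2n1`: > 125000 nM

Compound 1 gives > 125000 nM, which is a limit of the assay and not a number. It has no numerical position in the series, and the other two compounds share its reading: the limit of > 125000 nM in this assay, at which 3 of the 3 values shown sit.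

The next compound is compound 4 `ClC(Cl)(Cl)c1nc(-c2ccco2)c2ccccc2n1`, in which furan-2-yl takes the place of phenyl on an aromatic carbon: furan-2-yl in place of phenyl on an aromatic carbon.

Among the compounds with values here, the one measured step is a step that the two limits leave unreadable from compound 1 to compound 2, so it offers no size to carry over to this change. No step beyond the scatter is expected in this assay, and no direction can be named. The expected at least 1.0-fold lower number from compound 1 to compound 4 (0.01 log units; that floor lies within the scatter) should be read in that light, and another limit would be no surprise. Compound 4 is estimated at 120000 nM, with an expected range of 60000 nM to 200000 nM.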

Compound 4, half-maximal inhibitory concentration: > 125000 nM
Compound 4 gave a limit, no number (the forecaster's own chance of this, stated with the estimate: 70%); at least 1.0-fold (0.01 log units) between middle value and limit.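

In this assay compound 4 gives > 125000 nM as a limit of the assay and not a number. Within the data shown here, compound 1 also stands at a limit, so no step from compound 1 to compound 4 can be read: the limit of > 125000 nM in this assay, at which 4 of the 4 values shown sit. The compounds shown leave open whether any group at this place gives a numerical reading.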